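Aryl chromanone ether series: from isoprenyl ether to fluorobenzyl ether

The source may hold more compounds than are shown below. What is called first, only, known or untested is meant among the compounds shown, and "the series" means these compounds.

Measured compounds:
Compound 1 `CCCOc1ccccc1C1CC(=O)c2ccccc2O1`: 43.6%
Compound 2 `CCCCCOc1ccccc1C1CC(=O)c2ccccc2O1`: 40.1%
Compound 3 `CC(C)=CCOc1ccccc1C1CC(=O)c2ccccc2O1`: 40.3%

In a functional assay on J774.A1 cells (Mus musculus) for inhibition, read by immunoassay, with a stated time of 12 h, tested at 30 uM (on this read-out higher numbers stand for more inhibition at the one concentration tested (going by the name of the read-out) and lower numbers for less inhibition), compound 3 stands second highest of the three numbers, and both its neighbours lie within the scatter: a number 0.2 percentage points higher from compound 2 to compound 3 (within the scatter) and a number 3.3 percentage points lower from compound 1 to compound 3 (within the scatter). The third measured step, a number 3.5 percentage points lower from compound 1 to compound 2 (within the scatter), is likewise within the scatter, so changing the chain on the saturated carbon bound to the aromatic oxygen has so far left the read-out essentially unchanged.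

Compound 4 `O=C1CC(c2ccccc2OCc2cccc(F)c2)Oc2ccccc21` differs from compound 3 in one place: 3-fluorophenyl in place of 2-methylprop-1-en-1-yl on a saturated chain carbon bound to an oxygen on an aromatic ring. Within the data shown here, no measured step introduces an aromatic ring at this place, so the three flat steps are the only guide. Compound 4 is therefore expected to give 41% in this assay, between 26% and 56%, a step of a number 0.7 percentage points higher from compound 3 to compound 4 (within the scatter) not expected to exceed the scatter.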

Compound 4, a percentage reported as inhibition, at one concentration (the size of the read-out at that concentration, not a potency): 92.7%
The estimate for compound 4 lay 51.7 percentage points below the measured number, and the stated range ends below it.
By their numbers in this assay, from the lowest: compounds 2, 3 and 1 (each within the scatter of the next); then compound 4.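

At this position, on a saturated chain carbon bound to an oxygen on an aromatic ring, the read-out in this assay is not indifferent to the group: 3-fluorobenzyl in place of 3-methylbut-2-en-1-yl gives a number 52.4 percentage points higher from compound 3 to compound 4 (beyond the scatter) and the other two steps are of like size, a number 52.6 percentage points higher from compound 2 to compound 4 (beyond the scatter) and a number 49.1 percentage points higher from compound 1 to compound 4 (beyond the scatter). The earlier chains, none of which carries a ring, had stayed within the scatter of one another. Nothing available explains this rise.

Among these compounds, compound 4 is the only one with an aromatic ring here, so the shares of the ring and the fluorine remain unseparated. On these data alone, whether plain benzyl, 4-fluorobenzyl or a chain ending in an amine would give a similar number stays open.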